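A Longer Chain on the Piperazine Nitrogen

The compounds below may be only part of what the source reports. "The series", "measured", "known", "first", "only" and "open" are said of these compounds alone.

Compound 1 `CC(C)n1c(=O)n(C(=O)NCCN2CCN(C)CC2)c2ccccc21` was tested in a functional assay for antagonist activity at 5-hydroxytryptamine receptor 4 (Cavia porcellus); a higher number here means a more potent compound, by a factor of ten per unit of this negative logarithm, a lower number a less potent compound. In this assay compound 1 gives only a limit of the assay, < 6, and not a measured number. Compound 2 `CCCn1c(=O)n(C(=O)NCCN2CCN(C)CC2)c2ccccc21` carries propyl in place of isopropyl on an aromatic nitrogen; in this assay compound 2 likewise gives only a limit, < 6. Compound 3 `CC(C)n1c(=O)n(C(=O)NCCN2CCN(C)CC2)c2cc(Cl)ccc21` carries chloro in place of hydrogen on an aromatic carbon; in this assay compound 3 also gives only a limit, < 6. The step that the two limits leave unreadable from compound 1 to compound 2 and the step that the two limits leave unreadable from compound 1 to compound 3 cannot be sized, since all three values sit at the limit of < 6 in this assay, at which 3 of the 3 values shown sit.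

Compound 4 `CCCN1CCN(CCNC(=O)n2c(=O)n(C(C)C)c3ccccc32)CC1` differs from compound 1 by ethyl in place of hydrogen on a saturated chain carbon bound to an amine nitrogen in a ring. Neither measured step touches this part of the molecule, and neither step could be read, so there is no measured guide to the size or direction of this change. Compound 4 is therefore expected to stay near the limit, with an estimated value of 5.6 in a range from 4.8 to 6.4. The expected step is a step that the limit leaves unreadable from compound 1 to compound 4, essentially no change beyond the scatter.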

Compound 4, negative logarithm of the antagonist equilibrium constant: 6.89
For compound 4 the middle estimate is 1.29 log units below the measured one; the whole stated range lies below it.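

Exchanging 4-methylpiperazin-1-yl for 4-propylpiperazin-1-yl gives a number at least 0.89 log units higher from compound 1 to compound 4 (beyond the scatter) in this assay, so the substituent on this ring nitrogen can clearly shift the antagonist read-out. This step gives only a minimum size, and the other two steps, at the aromatic nitrogen and the aromatic carbon, cannot be read at all. Compound 4 is the only one of these four compounds with a measured number rather than a limit: the limit of < 6 in this assay, at which 3 of the 4 values shown sit.

With only methyl and propyl at this position, the compounds shown cannot establish a trend, and it remains open whether an ethyl group, a butyl group or a longer chain ending in an amine would give a higher or lower value. Also open, as far as these compounds go, is whether propyl on the aromatic nitrogen or chloro on the aromatic carbon would change the value once 4-propylpiperazin-1-yl is in place.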